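Amide-nitrogen variation on a shared core

A few compounds are considered here, and "the series" means these few. Any claim that something is new, unique, unknown or untested is made for them only; others in the source may bear on it.

Measured so far in a functional assay on HeLa cells (Homo sapiens) for inhibition, read by MTT assay, with a stated time of 48 h; a lower number here means a stronger inhibitor, a higher number a weaker inhibitor:
compound 1 `COc1ccc2c(=O)c(/C=C/C(=O)Nc3cc(C)ccc3C)coc2c1` gives 58400 nM
compound 2 `COc1ccc2c(=O)c(/C=C/C(=O)NCc3ccccc3)coc2c1` gives 33400 nM
compound 3 `CCOc1ccc(NC(=O)/C=C/c2coc3cc(OC)ccc3c2=O)cc1` gives only the limit of this assay, > 100000 nM

Compound 3 thus stands at the top of the series with a limit rather than a number (the limit of > 100000 nM in this assay, at which 1 of the 3 values shown sits). Compound 4 `COc1ccc2c(=O)c(/C=C/C(=O)Nc3cccc(C)c3)coc2c1` differs from compound 3 by 3-methylphenyl in place of 4-ethoxyphenyl on an amide-type nitrogen. Within the data shown here, two measured steps bear on this change: an at least 2.9-fold higher number from compound 2 to compound 3 (0.47 log units; beyond the scatter), and an at least 1.7-fold higher number from compound 1 to compound 3 (0.23 log units; that floor lies within the scatter). Removing the 4-ethoxyphenyl in favour of a methyl-bearing phenyl is therefore expected to bring the number down in this assay, by roughly an at least 1.5-fold lower number from compound 3 to compound 4 (0.18 log units; that floor lies within the scatter). Compound 4 is estimated at 65000 nM, with a range from 30000 nM to 150000 nM.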

Compound 4, half-maximal inhibitory concentration: > 100000 nM
Compound 4 ended at the assay's limit; the forecaster's own chance of this, stated with the estimate: 30%; at least 1.5-fold (0.18 log units) between middle value and limit.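

In this assay, compound 4 sits at a limit, as does compound 3, so the step between them cannot be read, and the series now clusters at this ceiling: the limit of > 100000 nM in this assay, at which 2 of the 4 values shown sit.
Benzyl in place of 3-methylphenyl separates the pair, with an at least 2.9-fold higher number from compound 2 to compound 4 (0.47 log units; beyond the scatter) as the step beyond the scatter.
Hydrogen in place of methyl on an aromatic carbon gives an at least 1.7-fold higher number from compound 1 to compound 4 (0.23 log units; that floor lies within the scatter) and a floor within the scatter, so this change shows no clear effect.

Where compound 3 and compound 4 truly lie remains open.
Also open, on these data alone, is whether an amine or a carboxylic acid on the benzyl group, or a longer chain in its place, would lower the number.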